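From Compound 1 to Compound 4: a Naphthalen-2-yl Replacement

This account rests on a few compounds, and the source may have more. Where it says the series, first, only, none or still open, it means among the compounds named here.

Compound 1 `O=C(O)CCCCCCC(=O)Nc1ccc(C2=C(c3ccc(O)cc3)C3CC(S(=O)(=O)Oc4ccccc4C(F)(F)F)C2O3)cc1`: in a functional assay on DU-145 cells (Homo sapiens) for inhibition, read by MTT assay, with a stated time of 72 h (on this read-out higher numbers stand for weaker inhibition and lower numbers for stronger inhibition), compound 1 gives > 100000 nM, which is a limit of the assay and not a number.
Compound 2 `O=C(O)CCCCCCC(=O)Nc1cccc(OS(=O)(=O)C2CC3OC2C(c2ccc(O)cc2)=C3c2ccc(O)cc2)c1`: compound 2 gives > 100000 nM, also a limit.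
Compound 3 `COc1ccccc1OS(=O)(=O)C1CC2OC1C(c1ccc(NC(=O)CCCCCCC(=O)NO)cc1)=C2c1ccc(O)cc1`: compound 3 gives 44700 nM.

Compound 1 therefore stands only at a limit, (the limit of > 100000 nM in this assay, at which 2 of the 3 values shown sit), so it cannot be placed above or below compound 2, and compound 3 alone offers a measured number. Compound 4 `O=C(O)CCCCCCC(=O)Nc1ccc(C2=C(c3ccc(O)cc3)C3CC(S(=O)(=O)Oc4ccc5ccccc5c4)C2O3)cc1` has not been measured. It differs from compound 1 in one place: naphthalen-2-yl in place of 2-(trifluoromethyl)phenyl on an oxygen. Going by the values given here, no step between measured compounds is known here, so nothing shows how such a change shifts activity. The step of a number no higher from compound 1 to compound 4 (the limit leaves the size open) is expected to stay within the scatter, in no set direction. Compound 4 is estimated at 100000 nM, ranging from 30000 nM to 300000 nM, with a real chance that only a limit is reported again.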

Compound 4, half-maximal inhibitory concentration: 58300 nM
The estimate for compound 4 lay 1.7-fold (0.23 log units) above the measured number; measured number inside the range.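

Compound 4 gives 58300 nM, so with naphthalen-2-yl on this oxygen bonded to the sulfonyl sulfur, the assay returns a measured number and not a limit. The change amounts to an at least 1.7-fold lower number from compound 1 to compound 4 (0.23 log units; that floor lies within the scatter). Its true size stays open because compound 1 has only a limit: the limit of > 100000 nM in this assay, at which 2 of the 4 values shown sit.

The compounds shown leave open how an unsubstituted phenyl or a methyl on this oxygen would read. They also leave open whether naphthalen-2-yl would behave the same way in a compound with a longer chain in place of the present one.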